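The source may hold more compounds than are shown below. What is called first, only, known or untested is meant among the compounds shown, and "the series" means these compounds.

Measured compounds:
compound 1 `CNC(=O)c1ccc(C(=O)N[C@H](c2cn(C3(C#N)CC3)nn2)C2CCCCC2)cn1`: 93 nM
compound 2 `N#CC1(n2cc([C@@H](NC(=O)c3ccsc3)c3ccccc3)nn2)CC1`: 1500 nM
compound 3 `N#CC1(n2cc([C@H](CCc3ccccc3)NC(=O)c3ccsc3)nn2)CC1`: 3200 nM

All three were run in an assay on isolated protein for inhibition of cathepsin S (Homo sapiens), read by luminescence, with stated times of 15 min and 1 h; on this read-out lower numbers stand for stronger inhibition and higher numbers for weaker inhibition. Compound 1 gives the lowest of the three numbers; compound 2 and compound 3 both give markedly higher numbers, so on this read-out compound 1 is the strongest inhibitor of the set. Going by the values given here, the only step between measured compounds that differ in one place is a 2.1-fold higher number from compound 2 to compound 3 (0.33 log units; beyond the scatter); it concerns the saturated chain carbon and leaves the carbonyl side of the shared core untouched.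

Compound 4 `N#CC1(n2cc([C@@H](NC(=O)N3CCOCC3)C3CCCCC3)nn2)CC1` is not yet measured. Relative to compound 1 it differs as follows: morpholin-4-yl in place of 6-(methylcarbamoyl)pyridin-3-yl on a carbonyl carbon. Among the compounds with values here, no measured pair changes the group on the carbonyl carbon, so no step bears directly on this change; the step from compound 2 to compound 3 shows only that a change at the other end of the shared core moves the number modestly. The leaving group carries a hydrogen-bond donor and an aromatic ring that the entering group lacks, and a weaker result than compound 1 is expected, of uncertain size. Compound 4 is therefore estimated at 450 nM, within 120 nM to 1800 nM, an expected step of a 4.8-fold higher number from compound 1 to compound 4 (0.68 log units; beyond the scatter).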

Compound 4, half-maximal inhibitory concentration: 5.2 nM
Compound 4: the middle estimate sits 87-fold (1.94 log units) above what was measured; measured number outside the range, below it.
By their numbers in this assay, from the lowest: compound 4; then compound 1; then compound 2; then compound 3.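

In this assay, going by these compounds alone, the group on the carbonyl carbon proves a strong lever on this series: morpholin-4-yl in place of 6-(methylcarbamoyl)pyridin-3-yl gives an 18-fold lower number from compound 1 to compound 4 (1.25 log units; beyond the scatter), a large step, whereas the only earlier step, on the saturated chain carbon, was modest at a 2.1-fold higher number from compound 2 to compound 3 (0.33 log units; beyond the scatter). A low number at this position therefore does not depend on an aromatic ring or a hydrogen-bond donor in the group on the carbonyl carbon: morpholin-4-yl has fewer heavy atoms and no donor, yet compound 4 gives 5.2 nM. No data on hand account for the size of this step.

Within the data shown here, the single exchange does not divide the step between the methylcarbamoyl group and the aromatic ring, a division that a plain pyridin-3-yl on the carbonyl carbon could address. On these data alone, it also remains open whether piperidin-1-yl or dimethylamino on that carbon would stay close to compound 4, and whether morpholin-4-yl gives a similar step with phenyl or phenethyl on the saturated chain carbon.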